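Replacing acetamido with 4-methylpiperidin-1-yl on compound 3

This account rests on a few compounds, and the source may have more. Where it says the series, first, only, none or still open, it means among the compounds named here.

In a functional assay for inhibition, with Homo sapiens as the target (on this read-out lower numbers stand for stronger inhibition and higher numbers for weaker inhibition), compound 3 `CC(=O)Nc1ccc(Nc2nccc(-c3cccnc3)n2)cc1` gives 3600 nM. That value lies within the scatter of compound 2 `CC1CCN(c2ccc(Nc3nccc(-c4ccco4)n3)cc2)CC1` at 1800 nM. Compound 1 `CC(=O)N(C)c1ccc(Nc2nccc(-c3cccnc3)n2)cc1` gives 900 nM, which shows stronger inhibition. The gap between compound 1 and compound 3 lies beyond the scatter.

Compound 4 `CC1CCN(c2ccc(Nc3nccc(-c4cccnc4)n3)cc2)CC1` is compound 3 with 4-methylpiperidin-1-yl in place of acetamido on an aromatic carbon. Among the measured compounds shown here, only one measured step touches this spot, a 4.0-fold higher number from compound 1 to compound 3 (0.60 log units; beyond the scatter), where hydrogen replaces methyl on an amide-type nitrogen. It shows that a small edit to this group can move the number modestly, but it does not measure the new group. The closest guide is compound 2, which carries 4-methylpiperidin-1-yl but differs elsewhere in the core and gives 1800 nM. A small step toward a lower number is therefore expected in this assay, and the estimated change is a 2.0-fold lower number from compound 3 to compound 4 (0.30 log units; within the scatter). The estimated value for compound 4 is 1800 nM, with an expected range of 500 nM to 6000 nM.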

Compound 4, half-maximal inhibitory concentration: 500 nM
Beside the measured number, compound 4's estimate is 3.6-fold (0.56 log units) above it, within the range that was stated.
By their numbers in this assay, from the lowest: compounds 4, 1, 2 and 3 (each within the scatter of the next, the first and the last beyond it).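

In this assay, putting 4-methylpiperidin-1-yl in place of acetamido gives a 7.2-fold lower number from compound 3 to compound 4 (0.86 log units; beyond the scatter) and so shows that this aromatic carbon accepts a larger, ring-bearing group with no hydrogen-bond donor, while a 1.8-fold lower number from compound 1 to compound 4 (0.26 log units; within the scatter) leaves that group and acetyl(methyl)amino within the scatter of each other. With 4-methylpiperidin-1-yl held constant, pyridin-3-yl in place of furan-2-yl gives a 3.6-fold lower number from compound 2 to compound 4 (0.56 log units; beyond the scatter) and so shows that the other substituent on the shared core also moves the number. Nothing available explains why either change has this effect.

Still open, from the compounds shown here alone, is how an open-chain amine such as dimethylamino, a morpholine ring or a carboxylic acid would behave at this position. Also open, going by these compounds, is whether the step from furan-2-yl to pyridin-3-yl would be similar with acetamido in place of 4-methylpiperidin-1-yl.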